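Replacing the phenyl of compound 3 with propyl

A few compounds are considered here, and "the series" means these few. Any claim that something is new, unique, unknown or untested is made for them only; others in the source may bear on it.

compound 1, `O=C(Nn1c(-c2cccc([N+](=O)[O-])c2)nc2c(-c3ccc(Cl)cc3)n[nH]c2c1=O)c1ccccc1`: 94.3%
compound 2, `COc1cccc(Cc2nc3c(-c4ccc(Cl)cc4)n[nH]c3c(=O)n2NC(=O)c2ccccc2)c1`: 93.2%
compound 3, `O=C(Nn1c(CCc2ccccc2)nc2c(-c3ccc(Cl)cc3)n[nH]c2c1=O)c1ccccc1`: 85.6%

In a functional assay on DU-145 cells (Homo sapiens) for cytotoxicity, read by sulforhodamine B assay, with a stated time of 2 days, tested at 100 uM (on this read-out higher numbers stand for more inhibition at the one concentration tested (going by the name of the read-out) and lower numbers for less inhibition), the three measured compounds share one core and differ at a single carbon. Compound 3 stands nearest compound 2 and furthest from compound 1, yet a number 7.6 percentage points lower from compound 2 to compound 3 (within the scatter) and a number 8.7 percentage points lower from compound 1 to compound 3 (within the scatter) are both within the scatter, as is a number 1.1 percentage points lower from compound 1 to compound 2 (within the scatter). Compound 4, `CCCCCc1nc2c(-c3ccc(Cl)cc3)n[nH]c2c(=O)n1NC(=O)c1ccccc1`, differs from compound 3 by propyl in place of phenyl on a saturated chain carbon, two bonds along the chain from an aromatic carbon. Among the compounds with values here, no measured step trades an aromatic ring for a plain chain; the steps that bear on it, all within the scatter, only exchange one aromatic group for another. The step of a number 7.6 percentage points lower from compound 3 to compound 4 (within the scatter) is therefore expected to be small, if anything a slight fall. The estimate for compound 4 is 78%, ranging from 58% to 92%.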

Compound 4, a percentage reported as inhibition, at one concentration (the size of the read-out at that concentration, not a potency): 88.7%
Compound 4: middle estimate off by 10.7 percentage points, on the low side; measured number inside the range.
By their numbers in this assay, from the lowest: compounds 3, 4, 2 and 1 (each within the scatter of the next).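

In this assay a plain chain at this carbon, with no aromatic ring in the group, reads the same as the groups that carry one: phenyl to propyl gives a number 3.1 percentage points higher from compound 3 to compound 4 (within the scatter) and the comparisons with the other two give a number 4.5 percentage points lower from compound 2 to compound 4 (within the scatter) and a number 5.6 percentage points lower from compound 1 to compound 4 (within the scatter). An aromatic ring in this group is therefore not required for the inhibition seen at the one concentration tested. Nothing here gives a reason for this. With a single concentration, any difference in potency among these compounds stays hidden. From the compounds shown here alone, whether an amine, a carboxylic acid or a longer chain at this carbon would keep the number remains open.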